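Hydroxylated side chain on the dipropylamino pyrimidine series

A few compounds are considered here, and "the series" means these few. Any claim that something is new, unique, unknown or untested is made for them only; others in the source may bear on it.

Among the compounds with values here, compound 2 `CCCc1nc(-c2c(C)cc(C)cc2OC)nc(OC)c1N(CCC)CCC` gives 76 nM in an in vitro assay on IMR-32 cells for displacement of a labelled ligand from corticotropin-releasing factor receptor 1 (Homo sapiens) (a lower number here means a stronger inhibitor, a higher number a weaker inhibitor), the higher of the two numbers so far. Within the data shown here, compound 1 `CCCN(CCC)c1c(CC)nc(-c2c(C)cc(C)cc2OC)nc1OC` gives 22 nM in this assay, and the step of a 3.5-fold higher number from compound 1 to compound 2 (0.54 log units; beyond the scatter) is the only measured change at this chain. Compound 3 `CCCN(CCC)c1c(CC(C)(C)O)nc(-c2c(C)cc(C)cc2OC)nc1OC` carries a further change at the same chain: 1-hydroxy-1-methylethyl in place of ethyl on a saturated chain carbon bound to an aromatic carbon. Among the measured compounds shown here, the one measured step shows that lengthening the chain by a methyl at this place weakened binding modestly; the hydroxyl of compound 3 has no measured counterpart here. On that basis a small further weakening or no change beyond the scatter is expected for compound 3, which is estimated at 110 nM with a range of 35 nM to 350 nM in this assay. The expected step is therefore a 1.4-fold higher number from compound 2 to compound 3 (0.16 log units; within the scatter), with wide uncertainty.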

Compound 3, inhibition constant: 604 nM
Compound 3: the middle estimate sits 5.5-fold (0.74 log units) below what was measured; measured number above the stated range.
By their numbers in this assay, from the lowest: compound 1; then compound 2; then compound 3.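

In this assay the step of a 7.9-fold higher number from compound 2 to compound 3 (0.90 log units; beyond the scatter) puts 2-hydroxy-2-methylpropyl in place of propyl at this chain, and it shows that this position does not hold the level of the plain chains once the hydroxylated, branched group enters. Counted from the lowest number in the series, the change is a 27-fold higher number from compound 1 to compound 3 (1.44 log units; beyond the scatter) and is large, which makes compound 3 the weakest of the three in this assay and shows a sensitivity at this place that reaches well past the single added methyl of the earlier step. No measured evidence on the reason for this rise is at hand.

The compounds shown leave open whether the hydroxyl or the added branching carries the rise. A 2-methylpropyl chain without the hydroxyl, a 2-methoxy-2-methylpropyl chain and a straight hydroxypropyl chain at this place would separate the two.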